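The source may report more compounds than this note shows. Statements on the series, on what has been measured and on what is new or still open speak of the compounds shown alone.

Compound 1 `COc1cc2c(Oc3ccc(NC(=O)N/N=C/c4ccc(C(F)(F)F)cc4)cc3F)ccnc2cc1OCCCN1CCCCC1`: in a functional assay on A549 cells (Homo sapiens) for cytotoxicity, read by MTT assay, with a stated time of 72 h (on this read-out lower numbers stand for stronger inhibition and higher numbers for weaker inhibition), compound 1 gives 660 nM.
Compound 2 `COc1cc2c(Oc3ccc(NC(=O)N/N=C/c4ccc(Cl)cc4Cl)cc3F)ccnc2cc1OCCCN1CCCCC1`: in this assay compound 2 gives "not determined" (no result reported).

Compound 2 therefore stands nowhere on the numbers: it carries no value in this assay, and the only measured point among these compounds is compound 1. Compound 3 `COc1ccc(/C=N/NC(=O)Nc2ccc(Oc3ccnc4cc(OCCCN5CCCCC5)c(OC)cc34)c(F)c2)c(OC)c1` differs from compound 2 by 2,4-dimethoxyphenyl in place of 2,4-dichlorophenyl on a carbon with a double bond to nitrogen. Among the measured compounds shown here, with no measured step to lean on, any change in this assay from compound 2 to compound 3 cannot be sized; no direction can be claimed beyond the scatter. Taking compound 1 as the only anchor, compound 3 is estimated at 1200 nM, expected to fall between 300 nM and 6000 nM.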

Compound 3, half-maximal inhibitory concentration: 1400 nM
For compound 3 the middle estimate is 1.2-fold (0.07 log units) below the measured one; low and high end bracket the measured number.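

In this assay the aryl group on a carbon with a double bond to nitrogen now has a measured step: 2,4-dimethoxyphenyl in place of 4-(trifluoromethyl)phenyl brings a 2.1-fold higher number from compound 1 to compound 3 (0.33 log units; beyond the scatter). The read-out therefore responds, modestly, to this change, while the change from 2,4-dichlorophenyl cannot be read, since compound 2 has no value. Nothing measured here accounts for the step.

The compounds shown leave open how a 4-methoxyphenyl group or a pyridine ring would read at this place, and whether an amine on the aryl group would shift the number further.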